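Replacing 2,4-dimethoxyphenyl with furan-3-yl on the shared core

This account rests on a few compounds, and the source may have more. Where it says the series, first, only, none or still open, it means among the compounds named here.

Values in an ADME assay on BHK-21 cells (Mesocricetus auratus) for cytotoxicity, read by MTT assay; on this read-out lower numbers stand for higher toxicity in this test and higher numbers for lower toxicity in this test:
- Compound 1 `C/C(=N\NC(N)=S)c1ccc2c(c1)nc(-c1ccccc1)n2C1CCCCC1`: 38000 nM
- Compound 2 `C/C(=N\NC(N)=S)c1ccc2c(c1)nc(-c1ccc(C(F)(F)F)cc1)n2C1CCCCC1`: > 100000 nM (a limit of the assay, not a number)
- Compound 3 `COc1ccc(-c2nc3cc(/C(C)=N/NC(N)=S)ccc3n2C2CCCCC2)c(OC)c1`: 17000 nM

Compound 3 has the lowest number of the three, which makes it the most toxic in this test, and compound 1 is its nearest neighbour. Compound 4 `C/C(=N\NC(N)=S)c1ccc2c(c1)nc(-c1ccoc1)n2C1CCCCC1` keeps the shared core and the cyclohexyl group but carries furan-3-yl in place of 2,4-dimethoxyphenyl on an aromatic carbon. Within the data shown here, no measured compound carries furan-3-yl, so the evidence is indirect. Two measured steps bring in 2,4-dimethoxyphenyl at this same aromatic carbon, and both lower the number: a 2.2-fold lower number from compound 1 to compound 3 (0.35 log units; beyond the scatter) and an at least 5.8-fold lower number from compound 2 to compound 3 (0.76 log units; beyond the scatter). The group at this carbon can also raise the number, as an at least 2.6-fold higher number from compound 1 to compound 2 (0.42 log units; beyond the scatter) shows. Taking 2,4-dimethoxyphenyl away is therefore expected to move the number back up towards that of compound 1, at 38000 nM. The expected change in this assay is modest: a 2.1-fold higher number from compound 3 to compound 4 (0.31 log units; beyond the scatter). Compound 4 is estimated at 35000 nM, with an expected range of 14000 nM to 90000 nM.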

Compound 4, half-maximal cytotoxic concentration: > 100000 nM
Compound 4: a limit, no number (the forecaster's own chance of this, stated with the estimate: 15%); middle value at least 2.8-fold (0.45 log units) from the limit.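

In this assay, furan-3-yl at this aromatic carbon gives an at least 5.8-fold higher number from compound 3 to compound 4 (0.76 log units; beyond the scatter), and it also gives an at least 2.6-fold higher number from compound 1 to compound 4 (0.42 log units; beyond the scatter). A high number here therefore does not depend on the trifluoromethyl group of compound 2, since a five-membered aromatic ring with one hetero atom reaches the same assay limit. The step between compound 2 and compound 4 cannot be read, because neither compound has a number, only the limit: the limit of > 100000 nM in this assay, at which 2 of the 4 values shown sit.

The compounds shown do not separate the effect of the five-membered ring from that of its oxygen, which a thiophen-3-yl or pyrrole ring at this carbon could address. They also leave open whether a phenyl ring carrying an amine or a carboxylic acid would raise or lower the number.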